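Diol Tail in Place of Amide on a Kinase Inhibitor

This account rests on a few compounds, and the source may have more. Where it says the series, first, only, none or still open, it means among the compounds named here.

Compound 1, `CC(C)NC(=O)c1cc(-c2ccc(NS(=O)(=O)c3cccc(Cl)c3Cl)cc2)nc2[nH]ncc12`: 68 nM
Compound 2, `Cc1n[nH]c2nc(-c3ccc(NS(=O)(=O)c4cc(Cl)ccc4F)cc3)nc(OCCC(=O)N(C)C)c12`: 15 nM

Of the compounds shown here, two have so far been measured in an assay for inhibition of serine/threonine-protein kinase Sgk1 (Homo sapiens), with stated times of 30 min and 60 min, in the presence of a further agent that is not named here; on this read-out lower numbers stand for stronger inhibition and higher numbers for weaker inhibition. Compound 1 gives 68 nM and compound 2 gives 15 nM, so compound 2 stands at the lowest of the two numbers, with compound 1 its nearest neighbour at a gap that lies beyond the usual scatter. Compound 3, `Cc1n[nH]c2nc(-c3ccc(NS(=O)(=O)c4cc(Cl)ccc4F)cc3)nc(OCC(CO)CO)c12`, is not yet measured. It differs from compound 2 in one place: 2-hydroxy-1-(hydroxymethyl)ethyl in place of (dimethylcarbamoyl)methyl on a saturated chain carbon bound to an oxygen on an aromatic ring. Among the measured compounds shown here, no pair of measured compounds differing in a single place is available, so no step of this kind can be read from the numbers in hand; the change also leaves the shared core of compound 2 untouched and alters only the chain on its ether oxygen. The step of a 1.3-fold higher number from compound 2 to compound 3 (0.12 log units; within the scatter) is expected to be small, not beyond the scatter, in either direction. Compound 3 is therefore estimated at 20 nM, within a range from 7 nM to 60 nM.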

Compound 3, half-maximal inhibitory concentration: 1 nM
For compound 3 the middle estimate is 20-fold (1.30 log units) above the measured one; measured number below the stated range.
By their numbers in this assay, from the lowest: compound 3; then compound 2; then compound 1.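

In this assay, the chain on the ether oxygen turns out to be a place that matters: 2-hydroxy-1-(hydroxymethyl)ethyl in place of (dimethylcarbamoyl)methyl gives a 15-fold lower number from compound 2 to compound 3 (1.18 log units; beyond the scatter) while the shared core stays untouched. Among the compounds shown here, neither compound 1 nor compound 2 alone could show this, since they differ in more than one place and offered no step to read. Nothing measured here accounts for the size of this step.

This single pair cannot separate the loss of the dimethylamide from the gain of the two hydroxyl groups. As far as these compounds go, whether an amine, a carboxylic acid or a longer chain ending in hydroxyl would serve this position equally well stays open, as does whether the same tail would have any such effect on the core of compound 1.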